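A few compounds are considered here, and "the series" means these few. Any claim that something is new, unique, unknown or untested is made for them only; others in the source may bear on it.

Measured in a functional assay on HCT-116 cells (Homo sapiens) for antiproliferative activity, read by MTT assay, with a stated time of 48 h; on this read-out lower numbers stand for stronger inhibition and higher numbers for weaker inhibition:

- compound 1 (`CCCCC(CCO)n1cnc2c(Cl)ncnc21`): > 50000 nM, a limit and not a number
- compound 2 (`CCCCCCCC(CCO)n1cnc2c(Cl)ncnc21`): 4160 nM

Among the measured compounds shown here, compound 2 stands at 4160 nM, the only actual number available in this assay. Compound 1 offers only a limit, as the limit of > 50000 nM in this assay, at which 1 of the 2 values shown sits, records.

Compound 3 (`CCCCCCCCCCC(CCO)n1cnc2c(Cl)ncnc21`) differs from compound 2 by propyl in place of hydrogen on a saturated chain carbon, eight bonds along the chain from an aromatic nitrogen. For the measured compounds named here, one measured step bears on this change. The same exchange, made five bonds along the chain from an aromatic nitrogen, gave an at least 12-fold lower number from compound 1 to compound 2 (1.07 log units; beyond the scatter). That large step points toward a lower number for compound 3 as well, but a single step establishes no trend, and the new site lies further out along the chain. A smaller step in the same direction is therefore expected, and a flat or reversed result cannot be excluded. The expected change is a 2.8-fold lower number from compound 2 to compound 3 (0.44 log units; beyond the scatter). For compound 3, the estimated value is 1500 nM, with an expected range of 300 nM to 8000 nM.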

Compound 3, half-maximal inhibitory concentration: 4930 nM
Compound 3: the middle estimate sits 3.3-fold (0.52 log units) below what was measured, and the stated range covers the measured number.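

Propyl in place of hydrogen on a saturated chain carbon, eight bonds along the chain from an aromatic nitrogen, gave a 1.2-fold higher number from compound 2 to compound 3 (0.07 log units; within the scatter), so the two compounds cannot be told apart in this assay. The large step seen with the same exchange closer to the aromatic nitrogen therefore does not repeat at this new position, and among these three compounds, added chain length is not enough on its own to lower the number further. Hexyl in place of hydrogen, five bonds along the chain from an aromatic nitrogen, gave an at least 10-fold lower number from compound 1 to compound 3 (1.00 log units; beyond the scatter), though the true size of this step stays unknown, because compound 1 stands at a limit and not at a number: the limit of > 50000 nM in this assay, at which 1 of the 3 values shown sits.

The compounds shown leave open whether a longer chain would keep the number at this level or raise it, and where between compound 1 and compound 2 the drop sets in. They also leave open whether an amine or a carboxylic acid at the far end of the chain would fit this position as well as the plain alkyl end does.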